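The source may hold more compounds than are shown below. What is called first, only, known or untested is meant among the compounds shown, and "the series" means these compounds.

Measured so far: compound 1 `C=C(Br)C(=O)Nc1cccc(/C=C2\SC(=O)N(Cc3ccc(Cl)cc3)C2=O)c1`, 2700 nM; compound 2 `C=C(Br)C(=O)Nc1ccc(/C=C2\SC(=O)N(Cc3cccc(Cl)c3)C2=O)cc1`, 8900 nM; compound 3 `Nc1ccc(/C=C2\SC(=O)N(Cc3cccc(Cl)c3)C2=O)cc1`, 24000 nM.

In a functional assay on HeLa cells (Homo sapiens) for cytotoxicity, read by cell counting, with a stated time of 4 days (a higher number here means a weaker inhibitor, a lower number a stronger inhibitor), compound 2 gives the second-highest number among the measured compounds. Its nearest neighbour is compound 3, reached by a 2.7-fold higher number from compound 2 to compound 3 (0.43 log units; beyond the scatter); its furthest is compound 1, whose number is lower and beyond the scatter.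

Compound 4 `C=C(Br)C(=O)Nc1ccc(/C=C2\SC(=O)N(Cc3ccc(Cl)cc3)C2=O)cc1` keeps every atom of compound 2 but rearranges one ring: 4-chlorophenyl in place of 3-chlorophenyl on a saturated chain carbon bound to an amide-type nitrogen in a ring. For the measured compounds named here, no measured pair shows this exact change on an otherwise identical scaffold. The only step shown, from compound 2 to compound 3, alters a different part of the molecule and does not bear on it. Compound 1 carries the 4-chlorophenyl group but also differs elsewhere, so its values and those of compound 2 can only be compared, not attributed to one change. Going by the values given here, with no step to lean on, the expected step of a 1.4-fold lower number from compound 2 to compound 4 (0.14 log units; within the scatter) is small and of uncertain direction. Compound 4 is therefore estimated at 6500 nM, within a range from 2200 nM to 19000 nM.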

Compound 4, half-maximal inhibitory concentration: 2300 nM
For compound 4 the middle estimate is 2.8-fold (0.45 log units) above the measured one, within the range that was stated.
By their numbers in this assay, from the lowest: compounds 4 and 1 (each within the scatter of the next); then compound 2; then compound 3.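

Replacing 3-chlorobenzyl with 4-chlorobenzyl, with the atom count unchanged, gives a 3.9-fold lower number from compound 2 to compound 4 (0.59 log units; beyond the scatter) in this assay and is beyond the scatter, so the outcome at this position depends on where the chlorine sits on the ring. For the compounds shown here, the earlier compounds could not show this: their only single-change step, a 2.7-fold higher number from compound 2 to compound 3 (0.43 log units; beyond the scatter), concerns the (1-bromoethenyl)carbonyl group on the nitrogen and leaves the chlorophenyl group untouched. No available evidence explains why the 4-chlorophenyl compound gives the lower number.

Going by these compounds, it remains open whether a bromine or a methoxy group in place of the chlorine would give a similar difference between the two ring positions, and how a plain phenyl group would compare. On these data alone, it is also open whether the 4-chlorophenyl group would give a similar step in a compound carrying the free amine of compound 3.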